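Swapping a Halogen on the Pendant Phenyl Ring

The source may report more compounds than this note shows. Statements on the series, on what has been measured and on what is new or still open speak of the compounds shown alone.

Two compounds share one core and differ only in the ring attached to an aromatic nitrogen. Compound 1 `COc1cc2c(Oc3ccc(NC(=O)c4nn(-c5ccccc5C)c(=O)cc4C)cc3F)ccnc2cc1OCCCN1CCCCC1` carries a 2-methylphenyl there; in a functional assay on NCI-H460 cells (Homo sapiens) for inhibition, read by MTT assay, with a stated time of 72 h (on this read-out lower numbers stand for stronger inhibition and higher numbers for weaker inhibition), compound 1 gives 3220 nM. Compound 2 `COc1cc2c(Oc3ccc(NC(=O)c4nn(-c5cccc(F)c5)c(=O)cc4C)cc3F)ccnc2cc1OCCCN1CCCCC1` carries a 3-fluorophenyl instead, and in this assay compound 2 gives 360 nM, the lowest of the two numbers, the measured step being an 8.9-fold lower number from compound 1 to compound 2 (0.95 log units; beyond the scatter). Compound 3 `COc1cc2c(Oc3ccc(NC(=O)c4nn(-c5ccc(Cl)cc5)c(=O)cc4C)cc3F)ccnc2cc1OCCCN1CCCCC1` is not yet measured; it differs from compound 2 by 4-chlorophenyl in place of 3-fluorophenyl on an aromatic nitrogen. Among the measured compounds shown here, the one measured step changed both the kind of group and where it sits on that ring, so it speaks only loosely to exchanging one halogen for another at a different spot. For the measured compounds named here, with no closer precedent, compound 3 is expected to land near compound 2, a step of about a 1.2-fold higher number from compound 2 to compound 3 (0.07 log units; within the scatter), well within the usual scatter. The estimate for compound 3 is therefore 420 nM, ranging from 140 nM to 1300 nM.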

Compound 3, half-maximal inhibitory concentration: 460 nM
Beside the measured number, compound 3's estimate is 1.1-fold (0.04 log units) below it; the measured number falls inside the stated range.
By their numbers in this assay, from the lowest: compounds 2 and 3 (each within the scatter of the next); then compound 1.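

In this assay the exchange gives a 1.3-fold higher number from compound 2 to compound 3 (0.11 log units; within the scatter) so a 3-fluorophenyl and a 4-chlorophenyl on this aromatic nitrogen cannot be told apart, even though the halogen and its place on the ring both differ. Set against the 2-methylphenyl, the new ring gives a 7.0-fold lower number from compound 1 to compound 3 (0.85 log units; beyond the scatter) so the lower number seen with compound 2 is not confined to a single ring: both halogen-bearing rings stand beyond the scatter from compound 1. Nothing available explains why these two rings read alike or why compound 1 stands apart.

Still open, going by these compounds, is whether the halogen is needed at all, and whether its kind or its place matters more, since the two change together here. A plain phenyl ring, or a phenyl ring carrying an amine or a carboxylic acid, would show how widely this position accepts other groups.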